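Swapping a phenoxy group for a bicyclic amine: cytotoxicity outlook

This account rests on a few compounds, and the source may have more. Where it says the series, first, only, none or still open, it means among the compounds named here.

Measured so far:
- Compound 1 `COc1ccc2[nH]c(C(=O)N3CC(=O)N(Cc4ccccc4)[C@@H](COc4ccccc4)C3)cc2c1`: > 10000 nM
- Compound 2 `COc1ccc2[nH]c(C(=O)N3CC(=O)N(Cc4cccc(OC(F)F)c4)[C@@H](CN4CCC(c5ccccn5)CC4)C3)cc2c1`: > 100000 nM

Both compounds were tested in an ADME assay on Vero cells (Chlorocebus sabaeus) for cytotoxicity, with a stated time of 7 days; on this read-out higher numbers stand for lower toxicity in this test and lower numbers for higher toxicity in this test. For compound 1 the result is a limit of the test rather than a number, namely > 10000 nM. For compound 2 the result is likewise a limit, > 100000 nM. Compound 1 therefore stands at the limit of > 10000 nM in this assay, at which 1 of the 2 values shown sits; the other result sits at the limit of > 100000 nM in this assay, at which 1 of the 2 values shown sits. Among the measured compounds shown here, neither value is a measured number, so no step between the two can be read from them.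

Compound 3 `COc1ccc2[nH]c(C(=O)N3CC(=O)N(Cc4ccccc4)[C@@H](CN4CC5CCCC5C4)C3)cc2c1` has not yet been measured in this assay. It differs from compound 1 in one place: a group of 8 heavy atoms (7 carbon, 1 nitrogen; one five-membered non-aromatic ring of carbon only, one five-membered non-aromatic ring with 1 hetero atom) in place of a group of 7 heavy atoms (6 carbon, 1 oxygen; one six-membered aromatic ring of carbon only), on a saturated chain carbon bound to a saturated ring carbon.

For the measured compounds named here, with no measured step to lean on, the expectation for this assay is no change beyond the scatter, which is what the step that the limit leaves unreadable from compound 1 to compound 3 expresses. Compound 3 is expected to give about 30000 nM, within a range of 8000 nM to 150000 nM, and most likely the assay will again report only a limit.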

Compound 3, half-maximal cytotoxic concentration: 10600 nM
Beside the measured number, compound 3's estimate is 2.8-fold (0.45 log units) above it; the measured number falls inside the stated range.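

In this assay compound 1 gives only a limit of the test and not a number, so no step from compound 1 to compound 3 can be read: the limit of > 10000 nM in this assay, at which 1 of the 3 values shown sits.

The compounds shown leave open whether putting the new two-ring group in place of phenoxy on compound 1 raises, lowers or leaves unchanged the toxicity seen in this assay.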